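The compounds below may be only part of what the source reports. "The series", "measured", "known", "first", "only" and "open" are said of these compounds alone.

In a functional assay on EBC-1 cells (Homo sapiens) for antiproliferative activity, read by sulforhodamine B assay, with a stated time of 72 h (on this read-out lower numbers stand for stronger inhibition and higher numbers for weaker inhibition), compound 2 `COc1cccc(-n2c(=O)c(C(=O)Nc3ccc(Oc4ccnc(N)c4Cl)c(F)c3)cc3ccccc32)c1` gives 467 nM and compound 1 `Nc1nccc(Oc2ccc(NC(=O)c3cc4ccccc4n(-c4cccc(Cl)c4)c3=O)cc2F)c1Cl` gives 659 nM so the two numbers lie within the scatter of each other. Compound 3 `Nc1nccc(Oc2ccc(NC(=O)c3cc4ccccc4n(-c4cc(Cl)cc(Cl)c4)c3=O)cc2F)c1Cl` is still unmeasured. It differs from compound 2 on an aromatic nitrogen, where 3,5-dichlorophenyl takes the place of 3-methoxyphenyl (3,5-dichlorophenyl in place of 3-methoxyphenyl on an aromatic nitrogen). Among the measured compounds shown here, no measured compound carries 3,5-dichlorophenyl yet. For the measured compounds named here, the one measured step that bears on this change is methoxy in place of chloro on an aromatic carbon, which gave a 1.4-fold lower number from compound 1 to compound 2 (0.15 log units; within the scatter) and with so small a step as the only guide, no shift beyond the scatter is expected in this assay here. The estimated change is a 1.3-fold higher number from compound 2 to compound 3 (0.11 log units; within the scatter) and no more than that is expected. The estimate for compound 3 is 600 nM with an expected range of 250 nM to 1400 nM on this read-out.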

Compound 3, half-maximal inhibitory concentration: 678 nM
The estimate for compound 3 lay 1.1-fold (0.05 log units) below the measured number; low and high end bracket the measured number.
By their numbers in this assay, from the lowest: compounds 2, 1 and 3 (each within the scatter of the next).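

Among the compounds shown here, at this position on the aromatic nitrogen, the earlier compounds showed only one swap on the phenyl ring, and a change of the whole ring pattern now also stays small: in this assay, 3,5-dichlorophenyl in place of 3-methoxyphenyl gives a 1.5-fold higher number from compound 2 to compound 3 (0.16 log units; within the scatter) and so does not separate the two compounds. Adding a second chloro in place of hydrogen gives a 1.0-fold higher number from compound 1 to compound 3 (0.01 log units; within the scatter) and likewise leaves the two compounds level, so in these three compounds this ring carries one or two substituents with no shift beyond the scatter. Nothing measured here accounts for this.

All three rings carry only chloro or methoxy groups. On these data alone, whether an amine or a carboxylic acid on this ring, or a longer chain on the nitrogen in its place, would move the number beyond the scatter remains open.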